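The source may report more compounds than this note shows. Statements on the series, on what has been measured and on what is new or still open speak of the compounds shown alone.

Measured compounds:
Compound 1 `CCN(CC)CN1C(=O)/C(=N/NC(N)=S)c2ccccc21` gives 164000 nM in a functional assay on CCRF-CEM cells (Homo sapiens) for inhibition, read by cell counting, with a stated time of 72 h; on this read-out higher numbers stand for weaker inhibition and lower numbers for stronger inhibition.
Compound 2 `CCN(CC)CN1C(=O)/C(=N/NC(=S)Nc2ccc(C)cc2)c2ccccc21` gives 12000 nM in this assay.
Compound 3 `CCN(CC)CN1C(=O)/C(=N/NC(=S)Nc2ccc(Cl)cc2)c2ccccc21` gives 10000 nM in this assay.

Compound 3 holds the lowest of the three numbers, but its nearest neighbour, compound 2, stands within the scatter of it, so the two cannot be told apart; only compound 1, whose thiosemicarbazide end carries a bare hydrogen, sits far higher. The two large steps, a 14-fold lower number from compound 1 to compound 2 (1.14 log units; beyond the scatter) and a 16-fold lower number from compound 1 to compound 3 (1.21 log units; beyond the scatter), show that adding an aryl group on that nitrogen matters greatly, while the small step of a 1.2-fold lower number from compound 2 to compound 3 (0.08 log units; within the scatter) shows that exchanging what sits at the far end of that aryl group hardly matters.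

Compound 4 `CCN(CC)CN1C(=O)/C(=N/NC(=S)Nc2ccc(OC)cc2)c2ccccc21` keeps the aryl group and changes only its terminal substituent: methoxy in place of chloro on an aromatic carbon. The 4-chlorophenyl becomes 4-methoxyphenyl. For the measured compounds named here, the one step that bears on this, the methyl-to-chloro exchange, lay within the scatter, so a further exchange of that terminal group is expected to stay within the scatter as well, in neither direction. Compound 4 is therefore expected to give about 11000 nM in this assay, with a range from 4000 nM to 30000 nM. This estimate means a step of a 1.1-fold higher number from compound 3 to compound 4 (0.04 log units; within the scatter), expected to be negligible.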

Compound 4, half-maximal inhibitory concentration: 1900 nM
Estimate against measurement, compound 4: 5.8-fold (0.76 log units) above, and the stated range ends above it.
By their numbers in this assay, from the lowest: compound 4; then compounds 3 and 2 (each within the scatter of the next); then compound 1.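

The group at the far end of the aryl ring does matter in this assay after all: chloro and methyl could not be told apart, yet methoxy in place of chloro moves the number well beyond the scatter (a 5.3-fold lower number from compound 3 to compound 4 (0.72 log units; beyond the scatter)), and methoxy in place of methyl does so by a similar size (a 6.3-fold lower number from compound 2 to compound 4 (0.80 log units; beyond the scatter)). The gain from placing an aryl group on the amide-type nitrogen therefore depends on which aryl group it is, and the 4-methoxyphenyl group gives the largest step from the unsubstituted end of the series (an 86-fold lower number from compound 1 to compound 4 (1.94 log units; beyond the scatter)), so the earlier reading that this terminal group hardly matters holds only for the exchange of methyl and chloro. Nothing available explains why methoxy stands apart from chloro and methyl.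

The compounds shown leave open whether the oxygen link itself or the size of the group goes with the lower number, a question that a hydroxy group or a longer ethoxy chain at the same place would help to settle. They also leave open whether a methoxy group elsewhere on the ring, or an amine such as dimethylamino at this place, would give a number as low as that of compound 4.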